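The source may report more compounds than this note shows. Statements on the series, on what has been measured and on what is new or still open speak of the compounds shown alone.

Working notes on the series, read in a functional assay on T98G cells (Homo sapiens) for inhibition, read by MTT assay, with a stated time of 72 h; on this read-out lower numbers stand for stronger inhibition and higher numbers for weaker inhibition. Compound 1 (`CC1(C)CC(NC(=O)Nc2ccccc2Cl)c2cc(F)ccc2O1`) gives 27000 nM. Compound 2 (`CC1(C)CC(NC(=O)Nc2ccccc2)c2cc(Cl)ccc2O1`) gives 34000 nM. Within the data shown here, these are the only two numbers so far, and compound 2 stands level with compound 1, the gap lying within the scatter. The two compounds differ in more than one place, so no single-change step can be read from them.

Compound 3 (`CC1(C)CC(NC(=O)NCc2ccccc2)c2cc(Cl)ccc2O1`) has not yet been measured and keeps the core of compound 2. The change is benzyl in place of phenyl on an amide-type nitrogen. Among the measured compounds shown here, no measured pair shows this change, so the data give no direct guide to its size or direction in this assay. The expectation therefore rests on compound 2 at 34000 nM: no step beyond the scatter is expected, with no preferred direction and with a wide range. The estimated step is a 1.1-fold lower number from compound 2 to compound 3 (0.05 log units; within the scatter). For compound 3 the expected value is 30000 nM, with an estimated range from 12000 nM to 70000 nM.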

Compound 3, half-maximal inhibitory concentration: 15000 nM
The estimate for compound 3 lay 2.0-fold (0.30 log units) above the measured number; the range from low to high includes it.
By their numbers in this assay, from the lowest: compounds 3, 1 and 2 (each within the scatter of the next, the first and the last beyond it).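

In this assay, among these compounds, the anilino to benzylamino change gives the first step that can be read from a single change: a 2.3-fold lower number from compound 2 to compound 3 (0.36 log units; beyond the scatter) on the core of compound 2. This shows that the place on the amide-type nitrogen responds to a change of group, though only modestly, and that benzyl gives the lower number here while the six-membered aromatic ring of phenyl is kept. No measured finding is available to account for this step.

On these data alone, it remains open whether a longer chain such as phenethyl on the same nitrogen would continue this trend or reverse it, and whether an amine or a carboxylic acid on the aromatic ring of the benzyl group would be tolerated. A single pair on one core also leaves open whether the same change would give a step of similar size and direction on the core of compound 1, with its fluoro and chloro groups in place.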